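The source may hold more compounds than are shown below. What is called first, only, known or untested is meant among the compounds shown, and "the series" means these compounds.

Compound 2 `NCCOc1ccc2nc(-c3cn(-c4ccc(O)cc4)nn3)ccc2c1`: 3.7 ug/mL
Compound 1 `COCCOc1cccc(Oc2cccc3nc(-c4cn(-c5ccc(O)c(F)c5)nn4)ccc23)c1`: 6.1 ug/mL
Compound 3 `O=C(O)COCCOc1ccc2nc(-c3cn(-c4ccc(O)c(F)c4)nn3)ccc2c1`: 867 ug/mL

All three were measured in a physicochemical assay for solubility, read by spectrophotometry, using the shake flask method, with a stated time of 2 days, at pH 6.5; a lower number here means a less soluble compound, a higher number a more soluble compound. Compound 2 holds the lowest of the three numbers; compound 1 sits within the scatter of it, while compound 3 stands far beyond the scatter above it. Compound 4 `COCCOCCOc1ccc2nc(-c3cn(-c4ccc(O)cc4)nn3)ccc2c1` has not yet been measured. It differs from compound 2 in a single place: 2-methoxyethoxy in place of amino on a saturated chain carbon, two bonds along the chain from an oxygen on an aromatic ring. For the measured compounds named here, no measured pair shows this exact change, so the expectation rests on the numbers alone. In this assay only a small step is expected, probably not beyond the scatter, because compound 1 with its own 2-methoxyethoxy group gives 6.1 ug/mL. Compound 4 is thus estimated at about 4.5 ug/mL, within a range from 1.2 ug/mL to 17 ug/mL. The expected step is a 1.2-fold higher number from compound 2 to compound 4 (0.09 log units; within the scatter).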

Compound 4, solubility: 2.4 ug/mL
For compound 4 the middle estimate is 1.9-fold (0.27 log units) above the measured one; low and high end bracket the measured number.
By their numbers in this assay, from the lowest: compounds 4, 2 and 1 (each within the scatter of the next, the first and the last beyond it); then compound 3.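

In this assay, going from amino, with 1 heavy atom, to 2-methoxyethoxy, with 5 heavy atoms, gives a 1.5-fold lower number from compound 2 to compound 4 (0.19 log units; within the scatter) on this saturated chain carbon. This single change therefore leaves the read-out within the usual scatter, even though the hydrogen-bond donor of the amino group is lost and the chain grows. Nothing measured here gives a reason for this result.

From the compounds shown here alone, what remains open is whether a dimethylamino group or a still longer chain of ethoxy units in this place would also stay within the scatter. Going by these compounds, a morpholine ring on the same chain carbon is an equally open case.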